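The compounds below may be only part of what the source reports. "The series", "measured", "known", "first", "only" and "open" are said of these compounds alone.

Compound 1 `CCN(CC)CCCOc1cc2ncnc(Nc3ccc(C#N)cc3)c2cc1OC` — in a functional assay on SH-SY5Y cells (Homo sapiens) for antiproliferative activity, read by MTT assay, with a stated time of 72 h (a higher number here means a weaker inhibitor, a lower number a stronger inhibitor), compound 1 gives > 100000 nM, which is a limit of the assay rather than a number.
Compound 2 `COc1cc2c(Nc3ccc(C#N)cc3)ncnc2cc1OCCCN1CCC(N2CCCCC2)CC1` — in this assay compound 2 gives 9810 nM.

Compound 1 therefore stands at the limit of this assay, as the limit of > 100000 nM in this assay, at which 1 of the 2 values shown sits, records, and only a limit is known for it. Among the measured compounds shown here, the one measured step that changes the same place, an at least 10-fold lower number from compound 1 to compound 2 (1.00 log units; beyond the scatter), moved the number down out of the limit. Compound 3 `COc1cc2c(Nc3ccc(C#N)cc3)ncnc2cc1OCCCN1CCN(c2ccncc2)CC1` makes a related change at that place: 4-(pyridin-4-yl)piperazin-1-yl in place of diethylamino on a saturated chain carbon, three bonds along the chain from an oxygen on an aromatic ring. Because the change enters at the same site as in an at least 10-fold lower number from compound 1 to compound 2 (1.00 log units; beyond the scatter), a lowering of the number from compound 1 is expected, though the entering group differs from that of compound 2, so the size is uncertain. Compound 3 is estimated at 15000 nM in this assay, within 3000 nM to 80000 nM. That estimate means the expected step of an at least 6.6-fold lower number from compound 1 to compound 3 (0.82 log units; beyond the scatter).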

Compound 3, half-maximal inhibitory concentration: 31600 nM
Compound 3: middle estimate off by 2.1-fold (0.32 log units), on the low side, and the stated range covers the measured number.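

The lowering of the number is not tied to 4-(piperidin-1-yl)piperidin-1-yl alone: in this assay, 4-(pyridin-4-yl)piperazin-1-yl in place of diethylamino gives an at least 3.1-fold lower number from compound 1 to compound 3 (0.50 log units; beyond the scatter). The two entering groups are not interchangeable, however, with a 3.2-fold higher number from compound 2 to compound 3 (0.51 log units; beyond the scatter), so the identity of the group at this place affects the size of the step and not only its direction. The step from compound 1 gives only a minimum size, and its full size stays unknown, set by the limit recorded for compound 1: the limit of > 100000 nM in this assay, at which 1 of the 3 values shown sits.

The compounds shown leave open whether the pyridine ring matters, which 4-phenylpiperazin-1-yl in its place would test, and whether a single ring such as piperidin-1-yl or morpholin-4-yl already lowers the number. As far as these compounds go, whether the ranking of these groups holds on a longer chain also remains open.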